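The source may hold more compounds than are shown below. What is called first, only, known or untested is meant among the compounds shown, and "the series" means these compounds.

Measured so far in a functional assay on the whole organism with Mus musculus as the target; on this read-out lower numbers stand for an effect already at smaller amounts and higher numbers for an effect only at larger amounts of compound:
Compound 1 `CCNC(=O)/C=C/c1cccc(C(F)(F)F)c1`: 90 mg/kg
Compound 2 `CCC(O)CNC(=O)/C=C/c1cccc(C(F)(F)F)c1`: 90 mg/kg

In this pair, compound 1 stands level with compound 2, and nothing else measured offers a comparison. Compound 3 `CN1CCN(C(=O)/C=C/c2cccc(C(F)(F)F)c2)CC1` keeps the core of compound 1 but carries a new group on a carbonyl carbon: 4-methylpiperazin-1-yl in place of ethylamino on a carbonyl carbon. Within the data shown here, only one measured step bears on this, no change at the digits printed from compound 1 to compound 2 (within the scatter). It is a guide of limited reach, as it alters the ethylamino group rather than replacing it. No data show what replacing that group does in this assay, so neither direction can be favoured. No step beyond the scatter is therefore expected, though with wide uncertainty. The expected outcome is no change at the digits printed from compound 1 to compound 3 (within the scatter). For compound 3 the estimated value is 90 mg/kg, with an expected range from 35 mg/kg to 230 mg/kg.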

Compound 3, dose for half-maximal effect: > 100 mg/kg
Compound 3: only a limit was reported; the forecaster's own chance of this, stated with the estimate: 15%; middle value at least 1.1-fold (0.04 log units) from the limit.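

The value of compound 3 in this assay, > 100 mg/kg, is a limit and not a number: the limit of > 100 mg/kg in this assay, at which 1 of the 3 values shown sits.

With 4-methylpiperazin-1-yl in place of ethylamino on the carbonyl carbon, the data give an at least 1.1-fold higher number from compound 1 to compound 3 (0.04 log units; that floor lies within the scatter), and with the same group in place of (2-hydroxybutyl)amino they give an at least 1.1-fold higher number from compound 2 to compound 3 (0.04 log units; that floor lies within the scatter). Among these compounds, this is the first reading on replacing the whole group on the carbonyl carbon with one that brings a ring and no hydrogen-bond donor, but with both floors within the scatter, it does not establish a real loss of effect.

From the compounds shown here alone, how far the true value of compound 3 lies from the limit remains open. Also open, going by these compounds, is whether a piperidin-1-yl or a dimethylamino group on the carbonyl carbon would behave like 4-methylpiperazin-1-yl or like ethylamino.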